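This account rests on a few compounds, and the source may have more. Where it says the series, first, only, none or still open, it means among the compounds named here.

Measured compounds:
compound 1 `O=C(CSc1nc(Nc2ccccc2)c2ccccc2n1)Nc1cccc(Cl)c1` — 16500 nM
compound 2 `O=C(CSc1nc(Nc2ccccc2)c2ccccc2n1)Nc1ccc(Br)cc1` — 11500 nM

In a functional assay on MDA-MB-231 cells (Homo sapiens) for inhibition, read by MTT assay, with a stated time of 72 h (a lower number here means a stronger inhibitor, a higher number a weaker inhibitor), compound 2 gives 11500 nM and compound 1 gives 16500 nM; the two are separated only by a 1.4-fold lower number from compound 1 to compound 2 (0.16 log units; within the scatter), so the numbers do not set one compound apart from the other.

Compound 3 `O=C(CSc1nc(Nc2ccccc2)c2ccccc2n1)Nc1ccc(Cl)c(Cl)c1` differs from compound 2 by 3,4-dichlorophenyl in place of 4-bromophenyl on an amide-type nitrogen. Going by the values given here, the one measured step that bears on this position, from compound 1 to compound 2, is a 1.4-fold lower number from compound 1 to compound 2 (0.16 log units; within the scatter), a change of halogen and its place on the same ring that stayed within the scatter. The move to a ring carrying two chlorines is a change of the same kind, so no step beyond the scatter is expected in this assay, in either direction.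

For compound 3 the estimated step is a 1.2-fold lower number from compound 2 to compound 3 (0.06 log units; within the scatter). Compound 3 is therefore expected near 10000 nM, within a range of 4000 nM to 25000 nM.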

Compound 3, half-maximal inhibitory concentration: 14500 nM
For compound 3 the middle estimate is 1.5-fold (0.16 log units) below the measured one, and the stated range covers the measured number.
By their numbers in this assay, from the lowest: compounds 2, 3 and 1 (each within the scatter of the next).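

In this assay, going by these compounds alone, adding a second halogen to the ring gives a 1.1-fold lower number from compound 1 to compound 3 (0.06 log units; within the scatter), the first direct reading of chloro in place of hydrogen on an aromatic carbon. The exchange of 4-bromophenyl for 3,4-dichlorophenyl on the amide-type nitrogen gives a 1.3-fold higher number from compound 2 to compound 3 (0.10 log units; within the scatter), so the numbers do not set compound 3 apart from compound 1 or compound 2, and all three halogen-bearing rings remain indistinguishable here. Nothing available explains why these steps are this small.

From the compounds shown here alone, all three compounds carry only chloro or bromo on this ring, so the effect of an unsubstituted phenyl, or of a methoxy, amine or carboxylic acid group there, remains open. Going by these compounds, the shared core is the same throughout, so whether a change elsewhere would move the number beyond the scatter also remains open.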